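This account rests on a few compounds, and the source may have more. Where it says the series, first, only, none or still open, it means among the compounds named here.

Compound 2, `Nc1scc(-c2cccc(C(F)(F)F)c2)c1C(=O)c1ccccc1`, is the one member of this small set that returns a number: in a functional assay on CHO-K1 cells for agonist activity at adenosine receptor A1 (Homo sapiens), read by GTPgammaS binding (on this read-out higher numbers stand for an effect only at larger amounts of compound and lower numbers for an effect already at smaller amounts), compound 2 gives 15.8 uM, and that is the only number shown. Its bromo neighbour, compound 1, `Nc1sc(Br)c(-c2cccc(C(F)(F)F)c2)c1C(=O)c1ccccc1`, gives in this assay only a limit, > 10 uM. The step from compound 1 to compound 2 therefore cannot be read in size, a step that the limit leaves unreadable from compound 1 to compound 2, owing to the limit of > 10 uM in this assay, at which 1 of the 2 values shown sits. Compound 3, `Nc1sc(-c2ccc([N+](=O)[O-])cc2)c(-c2cccc(C(F)(F)F)c2)c1C(=O)c1ccccc1`, differs from compound 2 by 4-nitrophenyl in place of hydrogen on an aromatic carbon. Among the compounds with values here, no measured step bears on a change of this kind, so the expectation rests on compound 2 alone and is correspondingly wide. He expects for compound 3 no step beyond the scatter, a 1.1-fold lower number from compound 2 to compound 3 (0.02 log units; within the scatter). His estimate for compound 3 in this assay is accordingly 15 uM, with a range from 4 uM to 60 uM.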

Compound 3, concentration for half-maximal effect: > 10 uM
Compound 3: only a limit was reported (the forecaster's own chance of this, stated with the estimate: 35%); the middle value does not contradict the limit.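

Neither the step from compound 2 to compound 3 nor the one from compound 1 to compound 3 can be read in size, due to a single feature of the data: the limit of > 10 uM in this assay, at which 2 of the 3 values shown sit.

The compounds shown leave open whether 4-nitrophenyl or bromo in place of hydrogen on that aromatic carbon changes the number at all, and in which direction.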